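Swapping the nitrogen substituent on a low free fraction

The source may hold more compounds than are shown below. What is called first, only, known or untested is meant among the compounds shown, and "the series" means these compounds.

- In an ADME assay for protein binding, using equilibrium dialysis, at pH 7.4, tested at 2 uM (on this read-out lower numbers stand for a smaller free fraction and higher numbers for a larger free fraction), compound 1 `CC(C)(C)C#Cc1cc(N(C(=O)[C@H]2CC[C@H](C)CC2)[C@H]2C[C@@H](Oc3cccnc3)C2)c(C(=O)O)s1` gives 0.04
- In this assay compound 2 `C[C@@H](CCOc1cccnc1)N(c1cc(C#CC(C)(C)C)sc1C(=O)O)C(=O)[C@H]1CC[C@H](C)CC1` gives 0.02

Among the measured compounds shown here, only two numbers exist so far, and they stand level within the scatter of repeated measurements. For the measured compounds named here, the single measured step is a 2.0-fold lower number from compound 1 to compound 2 (0.30 log units; within the scatter) and it changes the group on an amide-type nitrogen while the rest of the molecule stays the same.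

Compound 3 `CC(C)(C)C#Cc1cc(N(C(=O)[C@H]2CC[C@H](C)CC2)[C@H]2CC[C@H](O)CC2)c(C(=O)O)s1` changes that same place again. It carries 4-hydroxycyclohexyl in place of 1-methyl-3-((pyridin-3-yl)oxy)propyl on an amide-type nitrogen and so gives up the six-membered aromatic ring. Going by the values given here, no measured compound carries the entering group, so the evidence is thin. Among the compounds with values here, the one relevant guide is the step above, which stayed within the scatter. A larger swap could still move the number further, and a modest rise seems more likely than a fall, but nothing here shows it.

The estimated step is a 2.0-fold higher number from compound 2 to compound 3 (0.30 log units; within the scatter) and no move beyond the scatter is expected. The expected value for compound 3 is 0.04 with an estimated range from 0.015 to 0.1 in this assay terms.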

Compound 3, unbound fraction: 0.19
The estimate for compound 3 lay 4.8-fold (0.68 log units) below the measured number, and the stated range ends below it.
By their numbers in this assay, from the lowest: compounds 2 and 1 (each within the scatter of the next); then compound 3.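

The nitrogen position can move the free fraction after all: in this assay, putting 4-hydroxycyclohexyl in place of 1-methyl-3-((pyridin-3-yl)oxy)propyl gives a 9.5-fold higher number from compound 2 to compound 3 (0.98 log units; beyond the scatter), and putting it in place of 3-((pyridin-3-yl)oxy)cyclobutyl gives a 4.8-fold higher number from compound 1 to compound 3 (0.68 log units; beyond the scatter). Both steps lie beyond the scatter, unlike the earlier step between the two groups that carry the (pyridin-3-yl)oxy unit, so compound 3 has the highest number of the three and the largest share of unbound compound. The change does several things at once, removing the six-membered aromatic ring and its ring nitrogen and adding a hydrogen-bond donor, and nothing measured here singles out which of these matters.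

From the compounds shown here alone, it stays open whether the rise goes with gaining the hydroxy group or with losing the (pyridin-3-yl)oxy unit. Plain cyclohexyl on the same nitrogen would help to separate the two, and 4-aminocyclohexyl would show whether a different group on that ring gives a similar number.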